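Cyclohexyl in Place of Furanylmethyl on the Amide Nitrogen

This account rests on a few compounds, and the source may have more. Where it says the series, first, only, none or still open, it means among the compounds named here.

Compound 1 `N[C@H]1CC[C@H](Nc2c(C(=O)NCc3ccco3)nc(Br)c3cccnc23)CC1` was tested in a functional assay on SK-BR-3 cells (Homo sapiens) for cytotoxicity, read by MTT assay, with a stated time of 72 h (a higher number here means a weaker inhibitor, a lower number a stronger inhibitor), where compound 1 gives 10000 nM, the highest of the two numbers at hand. Compound 2 `N[C@H]1CC[C@H](NC(=O)c2nc(Br)c3cccnc3c2NCc2ccc(F)cc2)CC1` gives 2800 nM in this assay, a gap from compound 1 that lies beyond the usual scatter. Compound 3 `N[C@H]1CC[C@H](Nc2c(C(=O)NC3CCCCC3)nc(Br)c3cccnc23)CC1` differs from compound 1 by cyclohexyl in place of (furan-2-yl)methyl on an amide-type nitrogen. Among the measured compounds shown here, no measured pair shows this change, so the step is expected to be a 1.4-fold lower number from compound 1 to compound 3 (0.15 log units; within the scatter), within the scatter or leaning only slightly towards a lower number. Compound 3 is therefore estimated at 7000 nM, with a range from 2500 nM to 20000 nM.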

Compound 3, half-maximal inhibitory concentration: 4200 nM
For compound 3 the middle estimate is 1.7-fold (0.22 log units) above the measured one; the range from low to high includes it.
By their numbers in this assay, from the lowest: compounds 2 and 3 (each within the scatter of the next); then compound 1.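

In this assay the group on the amide-type nitrogen proves able to move the number: cyclohexyl in place of (furan-2-yl)methyl gives a 2.4-fold lower number from compound 1 to compound 3 (0.38 log units; beyond the scatter) as a modest step. A six-membered non-aromatic ring of carbon only, with no hydrogen-bond acceptor, is thus tolerated here in place of the five-membered aromatic ring. Nothing measured on these compounds accounts for the step. The compounds shown leave open how a cyclopropyl, a phenyl or a cyclohexyl carrying a hydroxyl would behave on this nitrogen.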